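Methyl to Trifluoromethyl on a Sulfonamide: Expected Tolerance of Compound 4

A few compounds are considered here, and "the series" means these few. Any claim that something is new, unique, unknown or untested is made for them only; others in the source may bear on it.

Compound 1, `Cc1ccc(S(=O)(=O)Nc2ccc(-c3nc4ccccc4o3)cc2)cc1`: in an ADME assay on HEK293 cells (Homo sapiens) for cytotoxicity, read by resazurin assay, with a stated time of 48 h (a higher number here means that more compound is tolerated, a lower number that less compound is tolerated), compound 1 gives 88000 nM.
Compound 2, `O=S(=O)(Nc1ccc(-c2nc3ccccc3o2)cc1)c1ccc(C(F)(F)F)cc1`: in this assay compound 2 gives 94000 nM.
Compound 3, `Cc1ccccc1S(=O)(=O)Nc1ccc(-c2nc3ccccc3o2)cc1`: in this assay compound 3 gives > 100000 nM, which is a limit of the assay rather than a number.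

The change from compound 1 to compound 2 is trifluoromethyl in place of methyl on an aromatic carbon, and it made a step of a 1.1-fold higher number from compound 1 to compound 2 (0.03 log units; within the scatter). The two cores differ as follows: 2-methylphenyl in place of 4-methylphenyl on a sulfonyl sulfur, with a step of an at least 1.1-fold higher number from compound 1 to compound 3 (0.05 log units; that floor lies within the scatter). Compound 4, `O=S(=O)(Nc1ccc(-c2nc3ccccc3o2)cc1)c1ccccc1C(F)(F)F`, is not yet measured; it differs from compound 3 by trifluoromethyl in place of methyl on an aromatic carbon. The surroundings of the place are not identical, para to a large group in one case and ortho to a large group in the other, so this is the same kind of change, not the same change. Compound 3 sits at the limit of > 100000 nM in this assay, at which 1 of the 3 values shown sits. Given the small step from compound 1 to compound 2, the step from compound 3 to compound 4 in this assay is expected to be about a step that the limit leaves unreadable from compound 3 to compound 4. Compound 4 is therefore estimated at 120000 nM, likely between 70000 nM and 250000 nM, and may again come back only as a limit.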

Compound 4, half-maximal cytotoxic concentration: > 100000 nM
Compound 4: no number, only a limit; the forecaster's own chance of this, stated with the estimate: 65%; the middle value is on the limit's open side.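

In this assay compound 4 gives > 100000 nM, a limit of the assay and not a number. Compound 3 stands at the same limit, so no step from compound 3 to compound 4 can be read: the limit of > 100000 nM in this assay, at which 2 of the 4 values shown sit.

The compounds shown leave open how much of compound 3 or compound 4 is actually tolerated, and so whether trifluoromethyl in place of methyl at this place changes tolerance at all.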